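Adding a hydroxy group to the propyl chain

A few compounds are considered here, and "the series" means these few. Any claim that something is new, unique, unknown or untested is made for them only; others in the source may bear on it.

Measured so far in a functional assay on cells (Homo sapiens) for antiproliferative activity, read by MTT assay, with a stated time of 48 h; a higher number here means a weaker inhibitor, a lower number a stronger inhibitor:
compound 1 `CCCn1c(N)c(-c2nc3ccccc3[nH]2)c2nc(C#N)c(C#N)nc21` gives > 50000 nM
compound 2 `CN(C)CCCn1c(N)c(-c2nc3ccccc3[nH]2)c2nc(C#N)c(C#N)nc21` gives 1820 nM
compound 3 `CN1CCN(CCCn2c(N)c(-c3nc4ccccc4[nH]3)c3nc(C#N)c(C#N)nc32)CC1` gives 4520 nM

The result of compound 1, > 50000 nM, is a limit of the assay and not a number.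

Compound 4 `N#Cc1nc2c(-c3nc4ccccc4[nH]3)c(N)n(CCCO)c2nc1C#N` shares the core of compound 1 and differs in one place: hydroxy in place of hydrogen on a saturated chain carbon, three bonds along the chain from an aromatic nitrogen. In simple terms, propyl becomes 3-hydroxypropyl.

The closest evidence comes from changes at this same chain carbon. Dimethylamino there gave an at least 27-fold lower number from compound 1 to compound 2 (1.43 log units; beyond the scatter), and 4-methylpiperazin-1-yl gave an at least 11-fold lower number from compound 1 to compound 3 (1.04 log units; beyond the scatter). Both steps are large, while the step between the two groups is modest: a 2.5-fold higher number from compound 2 to compound 3 (0.40 log units; beyond the scatter). Among the measured compounds shown here, no measured compound carries hydroxy, so these steps show that a change at this carbon can alter the result, but not what hydroxy will do.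

Compound 2 at 1820 nM and compound 3 at 4520 nM mark the size of gain seen with those two groups. A much smaller move in the same direction is expected in this assay, and compound 4 may well remain at the limit. The expected step is an at least 1.6-fold lower number from compound 1 to compound 4 (0.22 log units; that floor lies within the scatter). Compound 4 is estimated at 30000 nM, with an expected range from 8000 nM to 50000 nM.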

Compound 4, half-maximal inhibitory concentration: > 50000 nM
Compound 4: a limit, no number (the forecaster's own chance of this, stated with the estimate: 50%); middle value at least 1.6-fold (0.22 log units) from the limit.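

With 3-hydroxypropyl on the shared core, the result in this assay stays at the limit of the assay, so a new group at this chain carbon does not by itself give a readable result. Replacing either amine group with hydroxy shows how much depends on which group sits here, with an at least 27-fold higher number from compound 2 to compound 4 (1.43 log units; beyond the scatter) and an at least 11-fold higher number from compound 3 to compound 4 (1.04 log units; beyond the scatter); among the compounds shown, only those with dimethylamino or 4-methylpiperazin-1-yl give a number. The step between propyl and 3-hydroxypropyl cannot be read because both results are limits: the limit of > 50000 nM in this assay, at which 2 of the 4 values shown sit.

Any difference between those two chains therefore remains hidden, and hydroxy may have no effect at all or one too small to appear at this limit. A primary amine, morpholin-4-yl or a carboxylic acid on the same saturated chain carbon, or a longer chain carrying dimethylamino, would show how closely the lower numbers are tied to the groups in compound 2 and compound 3.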